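A few compounds are considered here, and "the series" means these few. Any claim that something is new, unique, unknown or untested is made for them only; others in the source may bear on it.

Measured so far in an assay for inhibition of histone deacetylase 8 (Homo sapiens), read by fluorescence, with stated times of 15 min and 60 min; a lower number here means a stronger inhibitor, a higher number a weaker inhibitor:

- compound 1, `Nc1ccccc1NC(=O)c1ccc(CNC2=N[C@H](Cc3ccccc3)CS2)cc1`: 12700 nM
- compound 2, `CC(=O)N1C(NCc2ccc(C(=O)Nc3ccccc3N)cc2)=NC(=O)C1Cc1ccccc1`: 22700 nM
- compound 3, `Nc1cc(C(=O)OCc2ccccc2)ccc1NC(=O)c1ccc(CNc2nccc(-c3cccnc3)n2)cc1`: > 20000 nM

Compound 1 and compound 2 each give a number in this assay. Compound 3 does not: its value is a limit of the assay, not a number, and it sits at the limit of > 20000 nM in this assay, at which 1 of the 3 values shown sits, so only the weak end of the range is known for it. Among the compounds with values here, compounds 1 and 2 both stand well toward the weak side too, but no step between them has been worked out, so their two values show only that neither is a strong inhibitor.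

Compound 4, `CC(C)(C)[Si](C)(C)OCc1ccc(NC(=O)c2ccc(CNc3nccc(-c4cccnc4)n3)cc2)c(N)c1`, is the next compound and has not yet been measured. It differs from compound 3 at one place: a group of 9 heavy atoms (7 carbon, 1 oxygen, 1 silicon; no ring) in place of a group of 10 heavy atoms (8 carbon, 2 oxygen; one six-membered aromatic ring of carbon only), on an aromatic carbon. The benzyloxycarbonyl leaves, and a group of 9 heavy atoms with no ring enters on an aromatic carbon. Within the data shown here, with compound 3 only known as a limit and no measured step to lean on, no step beyond the usual scatter can be expected in either direction, and compound 4 is estimated near the same weak end, a step that the limit leaves unreadable from compound 3 to compound 4. The expected value for compound 4 is 25000 nM, within a range of 8000 nM to 80000 nM.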

Compound 4, half-maximal inhibitory concentration: > 20000 nM
Compound 4: no number, only a limit; the forecaster's own chance of this, stated with the estimate: 60%; the middle value lies beyond the limit too.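

Compound 3 and compound 4 each give only a limit in this assay, not a number, so no step can be read between them: the limit of > 20000 nM in this assay, at which 2 of the 4 values shown sit.

From the compounds shown here alone, what stays open is how strongly either compound inhibits, and whether replacing benzyloxycarbonyl with the group of 9 heavy atoms changes that at all.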